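Vinyl sulfone catechols: chain terminus variation and a phenyl extension

The source may hold more compounds than are shown below. What is called first, only, known or untested is meant among the compounds shown, and "the series" means these compounds.

Measured compounds in a functional assay, read by fluorescence and spectrophotometry, with a stated time of 1 h; a higher number here means that more compound is needed for the effect, a lower number that less compound is needed:
- compound 1 `CCCCCS(=O)(=O)/C=C/c1ccc(O)c(O)c1` gives 8100 nM
- compound 2 `O=S(=O)(/C=C/c1ccc(O)c(O)c1)CC1CCCCO1` gives 10800 nM

Within the data shown here, compound 1 has the lower of the two numbers, but its only neighbour is compound 2, and the step of a 1.3-fold higher number from compound 1 to compound 2 (0.12 log units; within the scatter) is within the scatter, so the two compounds cannot be ordered. That single step swaps one saturated terminus for another on the carbon bound to the sulfonyl sulfur, and it shows the assay tolerating that change without a shift beyond the noise.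

Compound 3 `O=S(=O)(/C=C/c1ccc(O)c(O)c1)CCCc1ccccc1` is not yet measured. Its difference from compound 1 is phenyl in place of ethyl on a saturated chain carbon, three bonds along the chain from a sulfonyl sulfur. The change sits three bonds along the chain from the sulfonyl sulfur, not on the carbon bound to it, and it brings in a six-membered aromatic ring where the measured step brought in a saturated one. Among the measured compounds shown here, no measured step addresses an aromatic terminus, so the step from compound 1 to compound 2 is the only guide and it argues for little movement. The expected step is therefore a 1.2-fold lower number from compound 1 to compound 3 (0.06 log units; within the scatter), within the scatter and with no direction claimed. Compound 3 is estimated at 7000 nM, in a range from 3000 nM to 16000 nM.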

Compound 3, half-maximal effective concentration: 11500 nM
Compound 3: middle estimate off by 1.6-fold (0.22 log units), on the low side; the range from low to high includes it.
By their numbers in this assay, from the lowest: compounds 1, 2 and 3 (each within the scatter of the next).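

In this assay the exchange of ethyl for phenyl, on a saturated chain carbon three bonds along the chain from a sulfonyl sulfur, gives a 1.4-fold higher number from compound 1 to compound 3 (0.15 log units; within the scatter) and so does not separate the two compounds. The earlier step covered only a saturated terminus on the carbon bound to the sulfonyl sulfur, whereas this one shows that a six-membered aromatic ring of carbon only, with 6 heavy atoms entering where 2 leave, is also accommodated further out without a shift beyond the scatter. No evidence is at hand on what lies behind this flat response.

Open, on these data alone, is whether a terminus of another kind, such as an amine or a carboxylic acid in place of phenyl, would stay equally flat, or whether a longer chain ending in phenyl would finally move the number beyond the scatter. Also open, as far as these compounds go, is whether substituents on the phenyl ring, such as a methoxy group or a chlorine atom, would do so, and how much of the reading depends on the shared core, which is the same in all three compounds.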